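Methyl in Place of Chloro on the Pendant Phenyl Ring

The source may hold more compounds than are shown below. What is called first, only, known or untested is meant among the compounds shown, and "the series" means these compounds.

Compound 1 `CS(=O)(=O)c1ccc(-c2cnc3[nH]cc(-c4nnc(-c5ccc(F)cc5)o4)c(=O)c3c2)cc1`: 8.47%
Compound 2 `CS(=O)(=O)c1ccc(-c2cnc3[nH]cc(-c4nnc(-c5ccccc5)o4)c(=O)c3c2)cc1`: 8.58%
Compound 3 `CS(=O)(=O)c1ccc(-c2cnc3[nH]cc(-c4nnc(-c5ccc(Cl)cc5)o4)c(=O)c3c2)cc1`: 1.07%

Of the compounds shown here, three sharing one core have been tested in a functional assay on HeLa cells (Homo sapiens) for inhibition, read by MTT assay, with a stated time of 24 h, tested at 5 uM; a lower number here means less inhibition of growth, a higher number more inhibition of growth at the concentration tested. Compound 1 gives 8.47%, compound 2 gives 8.58%, and compound 3 gives 1.07%. Compound 3 holds the lowest of the three numbers, yet the steps of a number 7.4 percentage points lower from compound 1 to compound 3 (within the scatter) and a number 7.5 percentage points lower from compound 2 to compound 3 (within the scatter) both lie within the scatter, as does a number 0.1 percentage points higher from compound 1 to compound 2 (within the scatter), so no order among the three can be claimed.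

Compound 4 `Cc1ccc(-c2nnc(-c3c[nH]c4ncc(-c5ccc(S(C)(=O)=O)cc5)cc4c3=O)o2)cc1` has not yet been measured. It differs from compound 3 by methyl in place of chloro on an aromatic carbon. All three measured steps are swaps of a small group at this same place on the phenyl ring, and none of them moved the number beyond the scatter. On that basis a step of similar size, within the scatter, is expected for a number 4.9 percentage points higher from compound 3 to compound 4 (within the scatter). Compound 4 is therefore estimated to give 6% in this assay, with a likely range from -5% to 17%.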

Compound 4, percent growth inhibition at one concentration: 10.5%
Estimate against measurement, compound 4: 4.5 percentage points below; the measured number falls inside the stated range.
By their numbers in this assay, from the lowest: compounds 3, 1, 2 and 4 (each within the scatter of the next).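

With methyl, a fourth small group now stands at this place on the phenyl ring, para to a large group, and in this assay the swap from chloro gives a number 9.4 percentage points higher from compound 3 to compound 4 (within the scatter) as its step. Against the other two groups the steps are a number 1.9 percentage points higher from compound 2 to compound 4 (within the scatter) and a number 2 percentage points higher from compound 1 to compound 4 (within the scatter) and none of the three leaves the scatter, so methyl joins hydrogen, fluoro and chloro as groups among which no order can be claimed at this position. Nothing at hand bears on why the four numbers sit as they do.

As far as these compounds go, whether an amine, a carboxylic acid or a longer chain at this place would give a step beyond the scatter stays open. From the compounds shown here alone, all four compounds keep the rest of the shared core unchanged, so what a change elsewhere would do in this assay is equally open.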